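This account rests on a few compounds, and the source may have more. Where it says the series, first, only, none or still open, it means among the compounds named here.

Two compounds share one core and differ only at a single amide-type nitrogen. Compound 1 `Cc1cc(/C=C/C#N)cc(C)c1Oc1cc(Nc2ccc(C#N)cc2)c(N)cc1C(=O)NCCCO` carries a 3-hydroxypropyl group there, and in a physicochemical assay for solubility, read by HPLC, in phosphate buffer, with a stated time of 4 h, at pH 7.4 (a higher number here means a more soluble compound, a lower number a less soluble compound), compound 1 gives 1.01 ug/mL. Compound 2 `Cc1cc(/C=C/C#N)cc(C)c1Oc1cc(Nc2ccc(C#N)cc2)c(N)cc1C(N)=O` carries a hydrogen in its place, and in this assay compound 2 gives 0.63 ug/mL. The step of a 1.6-fold lower number from compound 1 to compound 2 (0.20 log units; within the scatter). For the measured compounds named here, compound 2 thus holds the lower of the two numbers, with compound 1 its only neighbour at a gap inside the scatter. Compound 3 `Cc1cc(/C=C/C#N)cc(C)c1Oc1cc(Nc2ccc(C#N)cc2)c(N)cc1C(=O)NCCC(F)F` is not yet measured; it differs from compound 2 by 3,3-difluoropropyl in place of hydrogen on an amide-type nitrogen. Going by the values given here, the one measured step at this nitrogen, a 1.6-fold lower number from compound 1 to compound 2 (0.20 log units; within the scatter), stayed within the scatter, so putting another short chain on the same nitrogen is expected to move this assay little, if at all. The expected step is a 1.1-fold lower number from compound 2 to compound 3 (0.02 log units; within the scatter). For compound 3 the estimate is 0.6 ug/mL, within a range from 0.25 ug/mL to 1.5 ug/mL.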

Compound 3, solubility: 6.59 ug/mL
Compound 3: middle estimate off by 11-fold (1.04 log units), on the low side; the measured number lies above the stated range.
By their numbers in this assay, from the lowest: compounds 2 and 1 (each within the scatter of the next); then compound 3.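

In this assay, the amide-type nitrogen turns out to tolerate a large shift: 3,3-difluoropropyl in place of hydrogen gives a 10-fold higher number from compound 2 to compound 3 (1.02 log units; beyond the scatter), whereas the earlier change at this nitrogen, a 1.6-fold lower number from compound 1 to compound 2 (0.20 log units; within the scatter), did not show one. The end of the chain also counts, not merely the presence of a chain: difluoromethyl in place of hydroxymethyl on a saturated chain carbon, two bonds along the chain from an amide-type nitrogen, gives a 6.5-fold higher number from compound 1 to compound 3 (0.81 log units; beyond the scatter). For the compounds shown here, nothing available here explains why this change moves the number so far.

The compounds shown leave open how a plain propyl chain, ending in neither hydroxyl nor fluorine, would compare, so the part played by the fluorine atoms stays unsettled. Going by these compounds, how a longer chain, or a chain ending in an amine or a carboxylic acid, would behave at this nitrogen also remains open.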